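The source may report more compounds than this note shows. Statements on the series, on what has been measured and on what is new or still open speak of the compounds shown alone.

Compound 1 `COc1ccc(S(=O)(=O)NC(C2=CC(=O)c3c(O)ccc(O)c3C2=O)C(C)C)cc1` gives 8950 nM
Compound 2 `CC(C)C(NS(=O)(=O)c1ccc(Cl)cc1)C1=CC(=O)c2c(O)ccc(O)c2C1=O` gives 8650 nM
Compound 3 `COc1ccc(S(=O)(=O)NC(C)C2=CC(=O)c3c(O)ccc(O)c3C2=O)cc1` gives 3760 nM

These numbers come from a functional assay on HeLa cells (Homo sapiens) for cytotoxicity, read by sulforhodamine B assay (a higher number here means a weaker inhibitor, a lower number a stronger inhibitor), and compound 3 has the lowest of the three, with the other two clearly higher. Compound 4 `CC(=O)c1ccc(S(=O)(=O)NC(C)C2=CC(=O)c3c(O)ccc(O)c3C2=O)cc1` has not yet been measured. It has acetyl in place of methoxy on an aromatic carbon compared with compound 3. The closest guide swaps the same methoxy for chloro on a different chain, giving a 1.0-fold lower number from compound 1 to compound 2 (0.01 log units; within the scatter) as its result. The chain change, a 2.4-fold lower number from compound 1 to compound 3 (0.38 log units; beyond the scatter) for its size, lies elsewhere and bears little on this swap. Acetyl itself is untested here, so the range stays wide. No step beyond the scatter is expected in this assay for this change. The expected result is a 1.0-fold higher number from compound 3 to compound 4 (0.00 log units; within the scatter) as estimated. For compound 4 the estimated value is 3800 nM with an expected range from 1800 nM to 8000 nM.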

Compound 4, half-maximal inhibitory concentration: 5760 nM
Compound 4: the middle estimate sits 1.5-fold (0.18 log units) below what was measured; the range from low to high includes it.
By their numbers in this assay, from the lowest: compounds 3, 4, 2 and 1 (each within the scatter of the next, the first and the last beyond it).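

In this assay, the change from 4-methoxyphenyl to 4-acetylphenyl gives a 1.5-fold higher number from compound 3 to compound 4 (0.19 log units; within the scatter). Until now, only chloro had replaced methoxy at this place, para to a large group, and only with isopropyl on the chain; this step adds a second replacement, acetyl, with methyl on the chain, and it also stays within the scatter. No measurement here bears on why this place tolerates both changes. From the compounds shown here alone, whether an amine or a carboxylic acid at this place would also stay within the scatter remains open.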